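The source may hold more compounds than are shown below. What is called first, only, known or untested is meant among the compounds shown, and "the series" means these compounds.

Three compounds that share one core and differ only in the group on a saturated chain carbon bound to a sulfur have been tested in a functional assay on PC-9 cells (Homo sapiens) for inhibition, read by MTT assay, with a stated time of 72 h; a higher number here means a weaker inhibitor, a lower number a stronger inhibitor. Compound 1 `Cc1cc(Nc2cc(-c3ccccc3)[nH]n2)n2nc(SCc3ccc([N+](=O)[O-])cc3)nc2n1`, carrying 4-nitrophenyl, gives 7980 nM. Compound 2 `Cc1cc(Nc2cc(-c3ccccc3)[nH]n2)n2nc(SCc3cccc(Br)c3)nc2n1`, carrying 3-bromophenyl, gives 8900 nM. Compound 3 `Cc1cc(Nc2cc(-c3ccccc3)[nH]n2)n2nc(SCc3ccccc3Br)nc2n1`, carrying 2-bromophenyl, gives 5630 nM.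

These numbers do not set compound 3 apart from the other two. The data show a 1.4-fold lower number from compound 1 to compound 3 (0.15 log units; within the scatter) and a 1.6-fold lower number from compound 2 to compound 3 (0.20 log units; within the scatter), and the remaining pair shows a 1.1-fold higher number from compound 1 to compound 2 (0.05 log units; within the scatter).

Compound 4 `Cc1cc(Nc2cc(-c3ccccc3)[nH]n2)n2nc(SCc3nc4ccccc4[nH]3)nc2n1` keeps the core but has 1H-benzimidazol-2-yl in place of 2-bromophenyl on a saturated chain carbon bound to a sulfur. Going by the values given here, no measured step makes this exact change. The closest evidence is the three swaps at the same place, and all of them stayed small. Among the compounds with values here, no tested compound carries 1H-benzimidazol-2-yl, so the range has to be wider than those steps suggest.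

On that basis, no step beyond the scatter is expected in this assay, and neither direction is favoured. The estimate for compound 4 is 7000 nM, with an expected range of 2500 nM to 20000 nM. This estimate means an expected 1.2-fold higher number from compound 3 to compound 4 (0.09 log units; within the scatter).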

Compound 4, half-maximal inhibitory concentration: 4840 nM
The estimate for compound 4 lay 1.4-fold (0.16 log units) above the measured number; measured number inside the range.
By their numbers in this assay, from the lowest: compounds 4, 3, 1 and 2 (each within the scatter of the next).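

In this assay, the position on a saturated chain carbon bound to a sulfur now carries something other than a single carbon ring: 1H-benzimidazol-2-yl brings a second ring, nitrogen atoms, a hydrogen-bond donor and a hydrogen-bond acceptor. Even so, the number stays within the scatter of all three earlier compounds, with (a 1.2-fold lower number from compound 3 to compound 4 (0.07 log units; within the scatter)), (a 1.6-fold lower number from compound 1 to compound 4 (0.22 log units; within the scatter)) and (a 1.8-fold lower number from compound 2 to compound 4 (0.26 log units; within the scatter)). The earlier compounds showed only that bromine or nitro variants of a phenyl group left the number in place, whereas compound 4 extends this to a quite different kind of ring group, though nothing presented here explains why the read-out stays so flat.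

The compounds shown leave open whether any group at this position can move the number beyond the scatter, for example an amine or a carboxylic acid in place of the ring, or a longer chain carrying the ring. From the compounds shown here alone, whether a change elsewhere would do so also remains open, as all four compounds keep the shared core unchanged.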